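The compounds below may be only part of what the source reports. "The series", "measured", "known", "first", "only" and "open" are said of these compounds alone.

Working notes on the series. Compound 1 `COc1cc(-n2ncnc2-c2ccc(OC(C)C)cc2)cc(OC)c1OC` is measured in a functional assay on A549 cells (Homo sapiens) for antiproliferative activity, read by MTT assay, with a stated time of 72 h (on this read-out lower numbers stand for stronger inhibition and higher numbers for weaker inhibition), at > 10000 nM, which is a limit of the assay rather than a number. Compound 2 `COc1cc(-c2ncnn2-c2ccc(Cl)c(Cl)c2)cc(OC)c1OC` gives > 10000 nM in this assay, again only a limit. Compound 3 `COc1cc(-c2ncnn2-c2ccc(F)cc2)cc(OC)c1OC` returns > 10000 nM in this assay, also a limit. Among the compounds with values here, only one single-point step has been measured so far, a step that the two limits leave unreadable from compound 2 to compound 3, and its size cannot be read because both of its ends sit at the limit of > 10000 nM in this assay, at which 3 of the 3 values shown sit. Compound 1 therefore stands where every other measured compound stands, at a limit with no number attached.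

Compound 4 `CCOc1ccc(-c2ncnn2-c2cc(OC)c(OC)c(OC)c2)cc1` differs from compound 1 by hydrogen in place of methyl on a saturated chain carbon bound to an oxygen on an aromatic ring and a saturated chain carbon. Within the data shown here, no measured step bears on this change, and the one step available gives no readable size to carry over. Among the measured compounds shown here, with every value so far at the limit and no informative step, the expectation for compound 4 is that it too sits at the limit, so the estimated step that the limit leaves unreadable from compound 1 to compound 4 is none beyond the scatter. Compound 4 is accordingly estimated at 20000 nM, with a range from 8000 nM to 60000 nM.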

Compound 4, half-maximal inhibitory concentration: 100 nM
Compound 4: middle estimate off by 200-fold (2.30 log units), on the high side; the measured number lies below the stated range.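

Going from isopropoxy to ethoxy in this assay gives an at least 100-fold lower number from compound 1 to compound 4 (2.00 log units; beyond the scatter), so this place on the chain, on a carbon bound to the aromatic oxygen, is the first point in the series where a change produces a readable value. Removing a single methyl here separates a compound at the limit from one with a measured number, whereas the step between compound 2 and compound 3 and its change on the aromatic nitrogen could not be read. The true size of the new step remains open-ended, because compound 1 gives only a limit of the assay: the limit of > 10000 nM in this assay, at which 3 of the 4 values shown sit.

The compounds shown leave open whether a methoxy or an n-propoxy group at this place would retain the value of compound 4. They also leave open whether the sharp drop from isopropoxy to ethoxy reflects branching or chain size.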